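The source may hold more compounds than are shown below. What is called first, only, known or untested is meant among the compounds shown, and "the series" means these compounds.

Measured so far in a functional assay on T-24 cells (Homo sapiens) for antiproliferative activity, read by MTT assay, with a stated time of 48 h; on this read-out higher numbers stand for weaker inhibition and lower numbers for stronger inhibition:

compound 1, `Cc1ccc(NC(=O)Nc2cccc(CNc3nccnc3Cl)c2)cc1C`: 8930 nM
compound 2, `O=C(Nc1cccc(CNc2nccnc2Cl)c1)Nc1ccc(Cl)cc1Br`: 6650 nM
compound 3, `O=C(Nc1ccc(Cl)cc1)Nc1cccc(CNc2nccnc2Cl)c1`: 5470 nM

Compound 3 gives the lowest number of the three, but its distance from the others is small: a 1.2-fold lower number from compound 2 to compound 3 (0.08 log units; within the scatter) and a 1.6-fold lower number from compound 1 to compound 3 (0.21 log units; within the scatter) both stay within the scatter, so nothing here sets compound 3 apart from compound 1 or compound 2 in this assay.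

Compound 4, `Cc1ccc(NC(=O)Nc2cccc(CNc3nccnc3Cl)c2)c(C)c1`, has not been measured. It differs from compound 3 in one place: 2,4-dimethylphenyl in place of 4-chlorophenyl on an amide-type nitrogen. Going by the values given here, the step that bears most directly is the one from compound 1 to compound 3, where 3,4-dimethylphenyl was exchanged for 4-chlorophenyl and the number moved by a 1.6-fold lower number from compound 1 to compound 3 (0.21 log units; within the scatter). Compound 4 reverses that kind of exchange, going back from 4-chlorophenyl to a dimethylphenyl, now 2,4-dimethylphenyl. The other exchanges on the same amide-type nitrogen, a 1.3-fold lower number from compound 1 to compound 2 (0.13 log units; within the scatter) and a 1.2-fold lower number from compound 2 to compound 3 (0.08 log units; within the scatter), were likewise within the scatter. All three measured variations of this group leave the number essentially where it was, so no shift beyond the scatter is expected for compound 4, perhaps a slightly higher number in line with compound 1.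

The expected step is a 1.4-fold higher number from compound 3 to compound 4 (0.14 log units; within the scatter). Compound 4 is estimated at 7500 nM, in the range 3500 nM to 16000 nM.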

Compound 4, half-maximal inhibitory concentration: 9230 nM
For compound 4 the middle estimate is 1.2-fold (0.09 log units) below the measured one; the measured number falls inside the stated range.
By their numbers in this assay, from the lowest: compounds 3, 2, 1 and 4 (each within the scatter of the next).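

In this assay, 2,4-dimethylphenyl on the amide-type nitrogen stays within the scatter of all three earlier groups: the exchange for 4-chlorophenyl gives a 1.7-fold higher number from compound 3 to compound 4 (0.23 log units; within the scatter) and the exchange for 2-bromo-4-chlorophenyl gives a 1.4-fold higher number from compound 2 to compound 4 (0.14 log units; within the scatter) as the widest and a middling step of the set. The new comparison is between two dimethylphenyl patterns, and 2,4-dimethylphenyl in place of 3,4-dimethylphenyl gives a 1.0-fold higher number from compound 1 to compound 4 (0.01 log units; within the scatter) with no visible effect on the number, so this pair adds a methyl rearrangement to the halogen and methyl exchanges that leave this assay read-out unmoved. Across the four aryl groups at this position, no exchange separates any compound from another, and nothing available explains this flatness.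

From the compounds shown here alone, all four compounds keep the shared core and carry only chloro, bromo or methyl on this phenyl ring, so it remains open whether a carboxylic acid, a dimethylamino group or a longer alkyl chain there would move the number beyond the scatter. Equally open, going by these compounds, is whether any change elsewhere on the shared core, away from the amide-type nitrogen, would matter more than the exchanges at this position.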